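Compounds 1 to 3: a ring methoxy lost

The source may hold more compounds than are shown below. What is called first, only, known or untested is meant among the compounds shown, and "the series" means these compounds.

Measured in a physicochemical assay, read by spectrophotometry, with a stated time of 30 min; on this read-out lower numbers stand for stronger inhibition and higher numbers for weaker inhibition:
- compound 1 `COc1cc(/C=N/NC(=O)CCCc2nc3ccccc3c(=O)[nH]2)ccc1O` gives 236000000 nM
- compound 2 `COc1cc(/C=N/NC(=O)CCCc2nc3ccccc3c(=O)[nH]2)cc(O)c1O` gives 88000000 nM

Compound 1 holds the higher of the two numbers at 236000000 nM. Compound 3 `O=C(CCCc1nc2ccccc2c(=O)[nH]1)N/N=C/c1ccc(O)cc1` carries hydrogen in place of methoxy on an aromatic carbon, ortho to a hydroxy group (hydrogen in place of methoxy on an aromatic carbon). For the measured compounds named here, only one measured step bears on this, and only indirectly: hydroxy in place of hydrogen on an aromatic carbon gave a 2.7-fold lower number from compound 1 to compound 2 (0.43 log units; beyond the scatter), a modest change. On that single precedent, a modest step towards a higher number is expected in this assay. The estimated step is a 1.7-fold higher number from compound 1 to compound 3 (0.23 log units; within the scatter). The expected value for compound 3 is 400000000 nM, within a range of 180000000 nM to 900000000 nM.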

Compound 3, half-maximal inhibitory concentration: 214000000 nM
Estimate against measurement, compound 3: 1.9-fold (0.27 log units) above; the range from low to high includes it.
By their numbers in this assay, from the lowest: compound 2; then compounds 3 and 1 (each within the scatter of the next).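

In this assay, the step of a 1.1-fold lower number from compound 1 to compound 3 (0.04 log units; within the scatter) shows that methoxy on this aromatic carbon, ortho to a hydroxy group, can give way to hydrogen without a difference that can be told from the scatter. Compound 1 and compound 3 therefore cannot be separated on this read-out, so this methoxy shows no measurable contribution here. No measurement in hand offers an explanation for this result.

Still open, going by these compounds, is whether an amine or a carboxylic acid on this carbon would read differently from methoxy or hydrogen. The same question stands for a longer chain such as butoxy.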